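Shortening the side chain of an epoxide ester

The source may hold more compounds than are shown below. What is called first, only, known or untested is meant among the compounds shown, and "the series" means these compounds.

Three compounds share a small three-membered oxygen ring carrying an ester and a long hydrocarbon chain, and all three have been tested in a functional assay for inhibition, with Rattus norvegicus as the target; a lower number here means that less compound is needed, a higher number that more compound is needed for the effect. Compound 1, `CCCCC/C=C/CCCCCCCCCC1(C(=O)OC)CO1`, gives 5 uM in this assay, the lowest of the three numbers. Compound 2, `CCCCCCCCCCCCCCC1(C(=O)OCCCC)CO1`, gives 10 uM, a number that sits within the usual scatter of the value for compound 1, so the two cannot be told apart. Compound 3, `CCCCCCC1(C(=O)OC)CO1`, gives 20 uM, which lies beyond that scatter and so is a clearly higher number than compound 1.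

Compound 4, `CCCCCCCCCCCC1(C(=O)OC)CO1`, has not yet been measured. It differs from compound 1 in one place: ethyl in place of hept-1-en-1-yl on a saturated chain carbon, nine bonds along the chain from a saturated ring carbon. The chain of compound 4 is therefore shorter than that of compound 1, yet longer than that of compound 3, and it carries no double bond.

Compound 3, with the shortest chain, needs the most material, and compound 1, with the longest, the least. On that basis compound 4 is expected to fall between them, with a step of a 2.0-fold higher number from compound 1 to compound 4 (0.30 log units; within the scatter) that goes toward a higher number and is about the size of the scatter. The estimate for compound 4 in this assay is 10 uM, with a range from 4 uM to 25 uM.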

Compound 4, minimum effective concentration: 2.5 uM
Beside the measured number, compound 4's estimate is 4.0-fold (0.60 log units) above it; the measured number lies below the stated range.
By their numbers in this assay, from the lowest: compounds 4, 1, 2 and 3 (each within the scatter of the next, the first and the last beyond it).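

Exchanging hept-1-en-1-yl for ethyl on a saturated chain carbon, nine bonds along the chain from a saturated ring carbon, gives a 2.0-fold lower number from compound 1 to compound 4 (0.30 log units; within the scatter) in this assay, so the much longer, unsaturated chain of compound 1 cannot be told apart from the saturated chain of compound 4. Pentyl in place of hydrogen on a saturated chain carbon, six bonds along the chain from a saturated ring carbon, gives an 8.0-fold lower number from compound 3 to compound 4 (0.90 log units; beyond the scatter), which shows that this added stretch of chain clearly lowers the amount of compound needed, whereas the further extension and double bond in compound 1 bring no change that can be distinguished from the scatter. Nothing available explains either result.

In the step between compound 1 and compound 4, chain length and the double bond change together, so a longer saturated chain with the length of compound 1 would be needed to separate their contributions. The compounds shown also leave open how a carboxylic acid or an amide in place of the methyl ester would behave on the chain of compound 4.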